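The source may report more compounds than this note shows. Statements on the series, on what has been measured and on what is new or still open speak of the compounds shown alone.

Measured so far in a functional assay on NCI-H226 cells (Homo sapiens) for inhibition, read by MTT assay, with a stated time of 48 h, tested at 10 uM; on this read-out lower numbers stand for less inhibition and higher numbers for more inhibition at the one concentration tested (going by the name of the read-out):
- compound 1 `Cc1ccc(Nc2cc(NC(=O)Nc3c(Cl)cccc3Cl)ncn2)cc1F` gives 40.7%;
- compound 2 `Cc1ccc(Nc2cc(NC(=O)Nc3c(Cl)cccc3Cl)ncn2)cc1C` gives 41.3%;
- compound 3 `COc1cc(Br)ccc1Nc1cc(NC(=O)Nc2c(Cl)cccc2Cl)ncn1` gives 43%.

Compound 3 has the highest of the three numbers, yet its gaps to the other two are both within the usual scatter, so the three read as one level and no order among them is claimed. The three measured steps say the same: a number 0.6 percentage points higher from compound 1 to compound 2 (within the scatter), a number 2.3 percentage points higher from compound 1 to compound 3 (within the scatter), a number 1.7 percentage points higher from compound 2 to compound 3 (within the scatter).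

Compound 4 `COc1ccc(Br)cc1Nc1cc(NC(=O)Nc2c(Cl)cccc2Cl)ncn1` is not yet measured. It differs from compound 3 in that (5-bromo-2-methoxyphenyl in place of 4-bromo-2-methoxyphenyl on a nitrogen on an aromatic ring); the two compounds hold the same atoms, joined differently. For the measured compounds named here, no measured step is of exactly this kind. The two that come nearest, a number 2.3 percentage points higher from compound 1 to compound 3 (within the scatter) and a number 1.7 percentage points higher from compound 2 to compound 3 (within the scatter), each swap the whole aryl group on that nitrogen and neither moves the read-out beyond the scatter. On that basis the step in this assay from compound 3 to compound 4 is expected to stay within the scatter, with no clear direction: a number 1 percentage points lower from compound 3 to compound 4 (within the scatter).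

Compound 4 is therefore estimated at 42% in this assay, with a range of 28% to 56%.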

Compound 4, a percentage reported as inhibition, at one concentration (the size of the read-out at that concentration, not a potency): 33%
The estimate for compound 4 lay 9 percentage points above the measured number; measured number inside the range.
By their numbers in this assay, from the lowest: compounds 4, 1, 2 and 3 (each within the scatter of the next).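

Working notes on the aryl group on the nitrogen, read in this assay: the exchange of 4-bromo-2-methoxyphenyl for 5-bromo-2-methoxyphenyl is the first step in the series that keeps the same atoms and the same counted donors and acceptors, and a number 10 percentage points lower from compound 3 to compound 4 (within the scatter) is the largest step seen so far, though it is still printed as within the scatter. The two whole-group swaps give the same reading, with a number 8.3 percentage points lower from compound 2 to compound 4 (within the scatter) and a number 7.7 percentage points lower from compound 1 to compound 4 (within the scatter) both leaving compound 4 on the level already set by the other three compounds, so the four aryl groups tested in this place show no order, and the rearrangement of the same atoms moves the read-out no further than the scatter allows. No measurement to hand bears on what lies behind these numbers.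

As far as these compounds go, whether the read-out in this assay separates beyond the scatter for any group in this place stays open, for instance with an aryl group carrying an amine or a carboxylic acid, or with ethoxy or a longer alkoxy chain in place of the methoxy. A single concentration also leaves open whether compounds on one level here would stay on one level at other concentrations.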